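The source may report more compounds than this note shows. Statements on the series, on what has been measured and on what is new or still open speak of the compounds shown alone.

Of the compounds shown here, three built on the shared core have been measured in a functional assay on COS-7 cells (Chlorocebus aethiops) for inhibition, read by MTT assay; a higher number here means a weaker inhibitor, a lower number a stronger inhibitor. Compound 1 `O=C1Nc2ccc(Br)cc2/C1=N/NC(=S)N/N=C/c1ccc(Br)cc1` gives 5180 nM in this assay. Compound 2 `Cc1ccc2c(c1)/C(=N/NC(=S)N/N=C/c1c(F)cccc1Cl)C(=O)N2` gives 2190 nM in this assay. For compound 3 `Cc1ccc2c(c1)/C(=N/NC(=S)N/N=C/c1ccc(-c3ccccc3)cc1)C(=O)N2` this assay returned only a limit, > 50000 nM, so compound 3 stands at the limit of > 50000 nM in this assay, at which 1 of the 3 values shown sits, and has no number of its own; it can only be said to sit at or beyond the weak end of what was seen. Compound 4 `Cc1ccc2c(c1)/C(=N/NC(=S)N/N=C/c1ccc(Br)cc1)C(=O)N2` is still to be measured in this assay. It differs from compound 3 by bromo in place of phenyl on an aromatic carbon. Going by the values given here, no measured pair shows this change on its own, so its size cannot be read directly from the data. Compound 1, whose outer arm also carries a bromo group, gives 5180 nM in this assay, and on that basis the step from compound 3 to compound 4 is expected to be large, toward stronger inhibition, at about an at least 11-fold lower number from compound 3 to compound 4 (1.04 log units; beyond the scatter). Compound 4 is therefore estimated to give roughly 4500 nM, within a range from 1200 nM to 20000 nM.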

Compound 4, half-maximal inhibitory concentration: > 50000 nM
Compound 4 ended at the assay's limit (the forecaster's own chance of this, stated with the estimate: 15%); at least 11-fold (1.04 log units) between middle value and limit.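

In this assay, bromo in place of phenyl on this aromatic carbon leaves the result at a limit of the assay, so the step between compound 3 and compound 4 cannot be read, and a bromo group here does not by itself bring a methyl-bearing compound into the measurable range: the limit of > 50000 nM in this assay, at which 2 of the 4 values shown sit. Two other changes can be sized: 4-bromophenyl in place of 2-chloro-6-fluorophenyl gives an at least 22-fold higher number from compound 2 to compound 4 (1.35 log units; beyond the scatter), and methyl in place of bromo on an aromatic carbon of the shared core gives an at least 9.6-fold higher number from compound 1 to compound 4 (0.98 log units; beyond the scatter). The outcome for this arm therefore depends on the group on the core, and the arm also matters with methyl on the core.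

Going by these compounds, how far compound 3 and compound 4 lie beyond the limit remains unknown. On these data alone, it also remains open whether an amine or a methoxy group at this position would give a measurable value with methyl on the core.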